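The compounds below may be only part of what the source reports. "The series", "measured", "known", "first", "only" and "open" are said of these compounds alone.

Measured so far:
compound 1 `CN(C[C@H]1Cc2c(cccc2N2CCN(Cc3ccccn3)CC2)CN1)[C@H]1CCCc2cccnc21` — 40.4%
compound 2 `CCCN(C[C@H]1Cc2c(cccc2N2CCNCC2)CN1)[C@H]1CCCc2cccnc21` — 87.4%

The study follows the step from compound 1 to compound 3 in an ADME assay on microsomes from liver (Mus musculus) for metabolic stability, read by LC-MS, with a stated time of 10 min; a higher number here means that more of the compound is left, a lower number that less of the compound is left. Among the measured compounds shown here, compound 1 gives 40.4%, the lower of the two numbers known; compound 2 gives 87.4%, a number that lies well beyond the scatter above compound 1. For the measured compounds named here, compound 2 differs from compound 1 in more than one place, so no single step can be drawn between them; their two values show only that the shared core can reach a much higher percent remaining than compound 1 does.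

Compound 3 `CN(C[C@H]1Cc2c(cccc2N2CCN(c3ccccn3)CC2)CN1)[C@H]1CCCc2cccnc21` is not yet measured. It differs from compound 1 in one place: pyridin-2-yl in place of (pyridin-2-yl)methyl on an amine nitrogen in a ring. The change removes one carbon from the group on the amine nitrogen in the ring and leaves the rest of compound 1 unchanged.

Going by the values given here, with no single-point step between measured compounds, the expectation rests on compound 1 alone. A small rise in this assay is expected, near the edge of the scatter, so that a number 9.6 percentage points higher from compound 1 to compound 3 (within the scatter) is the estimated step. Compound 3 is expected to give 50%, within a range from 25% to 75%.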

Compound 3, percent of the compound remaining: 46.1%
For compound 3 the middle estimate is 3.9 percentage points above the measured one; the measured number falls inside the stated range.
By their numbers in this assay, from the lowest: compounds 1 and 3 (each within the scatter of the next); then compound 2.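

In this assay, among the compounds shown here, the first step that can be read at this position is a number 5.7 percentage points higher from compound 1 to compound 3 (within the scatter), where the group on an amine nitrogen of a six-membered non-aromatic ring with 2 nitrogen changes from (pyridin-2-yl)methyl to pyridin-2-yl. Compound 1 and compound 3 therefore cannot be told apart in this read-out: taking away the one carbon that links the pyridine ring to the amine nitrogen leaves the percent remaining within the usual scatter, which neither earlier compound could show on its own. Nothing given here bears on why the two groups read alike.

For the compounds shown here, this single step covers only two closely related groups with the same aromatic ring, so it remains open whether a group of another kind on this amine nitrogen, such as an acetyl group, a phenyl ring or a longer chain like 2-(pyridin-2-yl)ethyl, would move the number beyond the scatter. As far as these compounds go, it also remains open whether the same step would read alike with a propyl group in place of the methyl group on the other amine nitrogen.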